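The source may hold more compounds than are shown below. What is called first, only, known or untested is meant among the compounds shown, and "the series" means these compounds.

Of the compounds shown here, three built on one shared core have been measured so far. Compound 1 `CN1CCN(CCCN(c2nc3cc(F)c(C(F)(F)F)cc3[nH]2)[C@@H]2CC[C@]3(c4ccc(C#N)cc4)C[C@H]23)CC1` gives 8.6 nM in an assay on isolated protein for binding affinity to melanin-concentrating hormone receptor 1 (Homo sapiens); a lower number here means a stronger inhibitor, a higher number a weaker inhibitor. Compound 2 `CN1CCN(CCCN(c2nc3cc(Cl)c(Cl)cc3[nH]2)[C@@H]2CC[C@]3(c4cccc(C#N)c4)C[C@H]23)CC1` gives 6.8 nM in this assay, and compound 3 `CN1CCN(CCCN(c2nc3cc(Cl)c(Cl)cc3[nH]2)[C@@H]2CC[C@]3(c4ccc(C#N)cc4)C[C@H]23)CC1` gives 11.4 nM, the highest of the three numbers, although its gaps to compound 1 and to compound 2 both fall inside the usual scatter of such measurements. Among the measured compounds shown here, the one measured single-point step, a 1.7-fold higher number from compound 2 to compound 3 (0.22 log units; within the scatter), concerns the cyanophenyl group and does not touch the part of the molecule changed next.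

Compound 4 `CN1CCN(CCCN(c2nc3cc(F)c(Cl)cc3[nH]2)[C@@H]2CC[C@]3(c4ccc(C#N)cc4)C[C@H]23)CC1` differs from compound 3 by fluoro in place of chloro on an aromatic carbon. For the measured compounds named here, no measured step isolates this change. Compound 1 and compound 3 differ at this position and at a second one as well, so their two values show only that both sit close together. Going by the values given here, with no step pointing in either direction, the change a 1.1-fold lower number from compound 3 to compound 4 (0.06 log units; within the scatter) is expected to stay within the scatter. Compound 4 is therefore estimated at 10 nM, with a range from 4 nM to 25 nM in this assay.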

Compound 4, inhibition constant: 4.9 nM
For compound 4 the middle estimate is 2.0-fold (0.31 log units) above the measured one; measured number inside the range.
By their numbers in this assay, from the lowest: compounds 4, 2, 1 and 3 (each within the scatter of the next, the first and the last beyond it).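

Fluoro in place of chloro now has a measured step of its own in this assay and gives a 2.3-fold lower number from compound 3 to compound 4 (0.37 log units; beyond the scatter), so this one-atom swap on the aromatic carbon, ortho to a chloro group, moves the number by a modest but readable amount. With that fluoro kept, chloro in place of trifluoromethyl on the other substituted aromatic carbon gives a 1.8-fold lower number from compound 1 to compound 4 (0.24 log units; within the scatter), so that second swap shows no readable change. Nothing measured here explains why the first swap moves the number.

The compounds shown leave open what a hydrogen, a methoxy group or an amine would give at this position. From the compounds shown here alone, it also remains open whether the fluoro for chloro swap would give a step of similar size with 3-cyanophenyl in place of 4-cyanophenyl.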